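Lengthening the acyl chain on a second core

The compounds below may be only part of what the source reports. "The series", "measured", "known", "first", "only" and "open" are said of these compounds alone.

Of the compounds shown here, three have been measured in an assay on isolated protein for inhibition of Nitric oxide synthase, inducible (Homo sapiens), read by scintillation counting, with a stated time of 30 min, tested at 50 uM; a lower number here means less inhibition, a higher number more inhibition at the concentration tested (going by the name of the read-out). Compound 1, `CCC(=O)N1N=C(c2cc(Cl)ccc2N)SC1(C)C`, carries a chloro group on its aromatic ring and a propanoyl chain; in this assay compound 1 gives 1.07%. Compound 2, `CCCC(=O)N1N=C(c2cc(Cl)ccc2N)SC1(C)C`, differs from compound 1 by methyl in place of hydrogen on a saturated chain carbon, two bonds along the chain from a carbonyl carbon, and this single change brings a number 65.1 percentage points higher from compound 1 to compound 2 (beyond the scatter), so compound 2 reaches 66.2% in this assay. Compound 3, `CCC(=O)N1N=C(c2ccccc2N)SC1(C)C`, keeps the propanoyl chain of compound 1 but differs in the core by hydrogen in place of chloro on an aromatic carbon, which gives a number 18.1 percentage points higher from compound 1 to compound 3 (beyond the scatter); compound 3 shows 19.2% in this assay.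

Compound 4, `CCCC(=O)N1N=C(c2ccccc2N)SC1(C)C`, has not yet been measured. It differs from compound 3 by methyl in place of hydrogen on a saturated chain carbon, two bonds along the chain from a carbonyl carbon, and this is the same change as that from compound 1 to compound 2, since the place on the chain reads identically for both pairs. Only the core differs between the two pairs, by hydrogen in place of chloro on an aromatic carbon.

The expectation is that this chain extension lifts inhibition on the second core as well, because the step of a number 65.1 percentage points higher from compound 1 to compound 2 (beyond the scatter) was large and the starting point of compound 3 leaves room for a rise of similar size. The step from compound 3 to compound 4 is therefore estimated at a number 45.8 percentage points higher from compound 3 to compound 4 (beyond the scatter) in this assay. For the measured compounds named here, compound 4 is expected to give about 65% in this assay, with a plausible range from 35% to 92%, since only one earlier example of the change exists.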

Compound 4, a percentage reported as inhibition, at one concentration (the size of the read-out at that concentration, not a potency): 35.2%
Estimate against measurement, compound 4: 29.8 percentage points above; measured number inside the range.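

In this assay, methyl in place of hydrogen on the chain raises the number on the second core as well, with a number 16 percentage points higher from compound 3 to compound 4 (beyond the scatter), so the direction carries over from one core to the other, but the size does not: the same change on two cores in this assay, a number 65.1 percentage points higher (beyond the scatter) from compound 1 to compound 2 and a number 16 percentage points higher (beyond the scatter) from compound 3 to compound 4, 49.1 percentage points apart, beyond the scatter of two such steps

Seen from the other side, hydrogen in place of chloro raised the number on the propanoyl compounds, yet on the propylcarbonyl compounds it gives a number 31 percentage points lower from compound 2 to compound 4 (beyond the scatter), so the effects of the two changes do not simply add up: the same change on two cores in this assay, a number 18.1 percentage points higher (beyond the scatter) from compound 1 to compound 3 and a number 31 percentage points lower (beyond the scatter) from compound 2 to compound 4, 49.1 percentage points apart, beyond the scatter of two such steps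

These four compounds show that the gain from the chain change depends on what else the core carries, but they do not show why, and two pairs cannot predict the size of the step on a further core, nor do readings at one concentration give a potency.

The compounds shown leave open whether a longer chain, such as pentanoyl, or a branched one, such as isobutyryl, would raise the number further on either core or bring it down again. They also leave open how a fluoro or a methoxy group in the place of the chloro would combine with each chain.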